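The source may report more compounds than this note shows. Statements on the series, on what has been measured and on what is new or still open speak of the compounds shown alone.

Measured compounds:

Compound 1 `O[C@H]1C[C@@H](Cn2cnc3c(Cl)ncnc32)c2ccccc21` — in an ADME assay on L1210/0 cells (Mus musculus) for cytotoxicity, with a stated time of 48 h (on this read-out higher numbers stand for weaker inhibition and lower numbers for stronger inhibition), compound 1 gives > 200000 nM, which is a limit of the assay, not a number.
Compound 2 `O=c1[nH]c(=O)n([C@@H]2C[C@H](CO)C[C@@H]2CO)cc1I` — in this assay compound 2 gives > 200000 nM, again a limit of the assay.
Compound 3 `COCC#Cc1cn([C@H]2C[C@H](O)[C@@H](CO)O2)c(=O)[nH]c1=O` — in this assay compound 3 gives > 200000 nM, also a limit of the assay.

Within the data shown here, compound 3 therefore stands at the same point as the other two: every value shown sits at the limit of > 200000 nM in this assay, at which 3 of the 3 values shown sit, and no compound has a number to compare with. Among the measured compounds shown here, no step between measured compounds is available.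

Compound 4 `C=CC#Cc1cn([C@H]2C[C@H](O)[C@@H](CO)O2)c(=O)[nH]c1=O` has not yet been measured. It differs from compound 3 in one place: vinyl in place of methoxymethyl on a triple-bonded carbon. The change is small in size, swaps one small chain for another on the alkyne, and leaves the rest of the shared core untouched.

With all three values at the limit, no direction can be read from the data. The expectation for compound 4 in this assay is no step beyond the scatter, the estimated change being a number no higher from compound 3 to compound 4 (the limit leaves the size open). Compound 4 is expected to give about 200000 nM, with a range from 50000 nM to 600000 nM, most likely reported as a limit again.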

Compound 4, half-maximal inhibitory concentration: > 200000 nM
Compound 4: no number, only a limit; the forecaster's own chance of this, stated with the estimate: 75%; the middle value sits exactly at the limit.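

No new step can be read between compound 3 and compound 4, and each stands only as a limit, not a number: the limit of > 200000 nM in this assay, at which 4 of the 4 values shown sit.

The compounds shown leave open whether any of them has a measurable potency in this assay and whether vinyl in place of methoxymethyl on a triple-bonded carbon changes it.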